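Amide-bearing pyrrolidine in place of methylpyrrolidine on a shared core

The compounds below may be only part of what the source reports. "The series", "measured", "known", "first", "only" and "open" are said of these compounds alone.

Two compounds share one core and differ only in the saturated amine attached to it. Compound 1 `O=C(CCc1ccc(C(F)(F)F)cc1)Nc1ccc2nc(N3CC4CC3CN4)ccc2c1` carries a bridged diamine, and in a functional assay on HEK293 cells for activation of melanin-concentrating hormone receptor 1 (Rattus norvegicus), read by inositol phosphate accumulation (a higher number here means that more compound is needed for the effect, a lower number that less compound is needed), compound 1 gives 490 nM. Compound 2 `CC1CCCN1c1ccc2cc(NC(=O)CCc3ccc(C(F)(F)F)cc3)ccc2n1` carries 2-methylpyrrolidin-1-yl instead; in this assay compound 2 gives 270 nM, the lowest of the two numbers, though the step of a 1.8-fold lower number from compound 1 to compound 2 (0.26 log units; within the scatter) lies within the scatter. Compound 3 `CC(C)C(=O)NC1CCN(c2ccc3cc(NC(=O)CCc4ccc(C(F)(F)F)cc4)ccc3n2)C1` is not yet measured. It differs from compound 2 by 3-((isopropylcarbonyl)amino)pyrrolidin-1-yl in place of 2-methylpyrrolidin-1-yl on an aromatic carbon, on an aromatic carbon of a six-membered aromatic ring with 1 nitrogen, part of a fused or bridged system of two rings, next to the ring nitrogen. For the measured compounds named here, the only measured step touching this position is a 1.8-fold lower number from compound 1 to compound 2 (0.26 log units; within the scatter), where exchanging one saturated amine for another moved the number very little. A similar outcome is therefore expected, a step of a 1.1-fold higher number from compound 2 to compound 3 (0.05 log units; within the scatter) that need not exceed the scatter. Compound 3 is estimated at 300 nM, with a range from 80 nM to 1200 nM.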

Compound 3, half-maximal effective concentration: 90 nM
Compound 3: the middle estimate sits 3.3-fold (0.52 log units) above what was measured; low and high end bracket the measured number.
By their numbers in this assay, from the lowest: compound 3; then compounds 2 and 1 (each within the scatter of the next).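

Compound 3 shows that this position, on an aromatic carbon next to the ring nitrogen, does respond to the choice of saturated amine in this assay: the earlier exchange stayed within the scatter, whereas a 3.0-fold lower number from compound 2 to compound 3 (0.48 log units; beyond the scatter) lies beyond it. The gain also holds against the bridged diamine, with a 5.4-fold lower number from compound 1 to compound 3 (0.74 log units; beyond the scatter), so 3-((isopropylcarbonyl)amino)pyrrolidin-1-yl, which adds a carbonyl and an amide hydrogen to the pyrrolidine ring, is accepted here and gives the lowest number of the three. No measurement available here explains this drop.

Still open, on these data alone, is which part of the new group goes with the lower number, since the amide and the isopropyl end entered together. A plain 3-aminopyrrolidin-1-yl, or an acetyl or longer pentanoyl chain on that amine, would help to separate these parts.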